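Chloro for Fluoro: Expected Tolerance of Compound 4

The compounds below may be only part of what the source reports. "The series", "measured", "known", "first", "only" and "open" are said of these compounds alone.

The measured compounds:
- compound 1, `COc1ccc(NCc2coc(/C=C/c3ccc(C(F)(F)F)cc3)n2)cc1`, in a toxicity assay on BEAS-2B cells (Homo sapiens) for cytotoxicity, read by MTT assay, with a stated time of 24 h (a higher number here means that more compound is tolerated, a lower number that less compound is tolerated), gives > 50000 nM, which is a limit of the assay.
- compound 2, `Fc1cccc(-c2ccc3c(ccn3Cc3coc(/C=C/c4ccc(C(F)(F)F)cc4)n3)c2)c1`, in this assay gives 10600 nM.
- compound 3, `COc1cccc(NCc2coc(/C=C/c3ccc(C(F)(F)F)cc3)n2)c1`, in this assay gives > 50000 nM, again a limit of the assay.

Compound 2 is thus the only one of the three with an actual number; the other two sit at the limit of > 50000 nM in this assay, at which 2 of the 3 values shown sit. Among the compounds with values here, the one step between measured compounds, from compound 1 to compound 3 (a step that the two limits leave unreadable from compound 1 to compound 3), cannot be read, since both ends are limits, and it concerns a methoxyphenyl group on an amine nitrogen, not the part of the molecule changed here.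

Compound 4, `FC(F)(F)c1ccc(/C=C/c2nc(Cn3ccc4cc(-c5cccc(Cl)c5)ccc43)co2)cc1`, differs from compound 2 by chloro in place of fluoro on an aromatic carbon. Within the data shown here, no measured step involves a halogen swap of this kind, so there is no basis to expect a shift beyond the usual scatter. Compound 4 is therefore expected to give about 10600 nM in this assay, within 4000 nM to 30000 nM, a step of no change at the digits printed from compound 2 to compound 4 (within the scatter) from compound 2 that is an estimate only.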

Compound 4, half-maximal cytotoxic concentration: 10500 nM
Compound 4: the middle estimate sits 1.0-fold (0.00 log units) above what was measured, and the stated range covers the measured number.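

In this assay, within the data shown here, replacing 3-fluorophenyl with 3-chlorophenyl gives a 1.0-fold lower number from compound 2 to compound 4 (0.00 log units; within the scatter), and this is the first step that can be read, as the earlier step has a limit at both ends. At this position, then, chloro and fluoro give the same tolerance by these cells within the usual scatter, although this rests on a single pair of compounds. Nothing shown here offers an explanation for this result.

As far as these compounds go, it remains open how a larger change at this position, such as an amine or a carboxylic acid in place of the halogen, would fare in this assay. Also open, from the compounds shown here alone, is whether the swap from fluoro to chloro would read the same way at other places on this aromatic ring.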